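Aryl urea series: ester in place of isopropyl

The source may report more compounds than this note shows. Statements on the series, on what has been measured and on what is new or still open speak of the compounds shown alone.

Measured so far in an ADME assay on the whole organism with Oryza sativa as the target, tested at 1 uM; a higher number here means a weaker effect of the compound at the concentration tested, a lower number a stronger effect:
compound 1, `CC(C)c1cccc(NC(=O)N[C@H](C)c2ccccc2)c1`, gives 61%
compound 2, `CC(C)c1cccc(NC(=O)N[C@@H](C)c2ccccc2)c1`, gives 84%
compound 3, `CCCCCCc1ccc(NC(=O)N[C@H](C)c2ccccc2)cc1`, gives 101%

Compound 2 stands second highest of the three numbers in this assay: compound 3 sits above it and compound 1 below it, both gaps beyond the scatter. Within the data shown here, the only single-place step among the measured compounds is a number 23 percentage points higher from compound 1 to compound 2 (beyond the scatter), a modest rise that follows from the fact that compounds 1 and 2 differ only in the configuration as drawn alone. Among the measured compounds shown here, compound 3 differs from compound 1 in more than one place, so its values show only that the hexyl compound is the highest of the three.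

Compound 4, `CCOC(=O)c1cccc(NC(=O)N[C@@H](C)c2ccccc2)c1`, is the next compound to be measured. Against compound 2 the change is ethoxycarbonyl in place of isopropyl on an aromatic carbon, with the stereocentre kept as in compound 2. For the measured compounds named here, no measured step bears on an exchange of the group on the aromatic ring; the stereo step from compound 1 to compound 2 says nothing about it. The step of a number 1 percentage points higher from compound 2 to compound 4 (within the scatter) is therefore expected to be small, with no direction claimed beyond the scatter, and the range kept wide. Compound 4 is estimated at 85% in this assay, between 60% and 105%.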

Compound 4, a percentage reported as activity, at one concentration (the size of the read-out at that concentration, not a potency): 99%
The estimate for compound 4 lay 14 percentage points below the measured number; measured number inside the range.
By their numbers in this assay, from the lowest: compound 1; then compound 2; then compounds 4 and 3 (each within the scatter of the next).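

In this assay, the group on this aromatic carbon, meta to a large group, is not indifferent to exchange: with ethoxycarbonyl in place of isopropyl and the stereocentre unchanged, the series shows a number 15 percentage points higher from compound 2 to compound 4 (beyond the scatter). Among these compounds, this is the first step read at this place on the ring, and it points towards a weaker effect at the concentration tested, whereas the earlier single-place step concerned configuration alone. The exchange brings more heavy atoms, two oxygens, a double bond outside the aromatic ring and two hydrogen-bond acceptors all at once, so the step cannot be assigned to any one of these, and nothing on record bears on its cause.

Open, on these data alone, is whether the same exchange gives a step of like size and direction with the stereocentre drawn as in compound 1, which gives 61% with isopropyl. A carboxylic acid, a primary amide or a methyl ester on the same aromatic carbon would show whether the step goes with the carbonyl or with the ethyl end of the ester.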